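Amide tail variation on the shared core

The source may report more compounds than this note shows. Statements on the series, on what has been measured and on what is new or still open speak of the compounds shown alone.

Compound 3 `CCN(CC)CCCNC(=O)c1ccc(C(CC)(CC)c2ccc(OCC(=O)C(C)(C)C)c(C)c2)n1CC` gives the lowest number of the three measured compounds in an assay on HL-60 cells for agonist activity at vitamin D3 receptor (Homo sapiens), read by microscopy, with a stated time of 96 h (on this read-out higher numbers stand for an effect only at larger amounts of compound and lower numbers for an effect already at smaller amounts), at 22 nM. Compound 2 `CCn1c(C(=O)NCCN(C)C)ccc1C(CC)(CC)c1ccc(OCC(=O)C(C)(C)C)c(C)c1` gives 77 nM and compound 1 `CC[C@@H](C)[C@H](NC(=O)c1ccc(C(CC)(CC)c2ccc(OCC(=O)C(C)(C)C)c(C)c2)n1CC)C(=O)OC` gives 590 nM; both a 7.7-fold lower number from compound 1 to compound 2 (0.88 log units; beyond the scatter) and a 27-fold lower number from compound 1 to compound 3 (1.43 log units; beyond the scatter) lie beyond the scatter. Compound 4 `CCn1c(C(=O)NCCN)ccc1C(CC)(CC)c1ccc(OCC(=O)C(C)(C)C)c(C)c1` differs from compound 3 only in the amide tail: amino in place of (diethylamino)methyl on a saturated chain carbon, two bonds along the chain from an amide-type nitrogen. The step that bears most directly on this is a 3.5-fold lower number from compound 2 to compound 3 (0.54 log units; beyond the scatter), which shows that the larger amine end gave the lower number in this assay; compound 4 goes further the other way, to a bare amino end on the shorter chain. The estimate for compound 4 is therefore an upward step of a 6.8-fold higher number from compound 3 to compound 4 (0.83 log units; beyond the scatter), beyond the scatter. Compound 2, which already carries the smaller dimethylamino end, gives 77 nM, and compound 4 is expected to land somewhat above that. Compound 4 is thus expected to give 150 nM, with a range of 40 nM to 550 nM.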

Compound 4, half-maximal effective concentration: 120 nM
The estimate for compound 4 lay 1.3-fold (0.10 log units) above the measured number, within the range that was stated.
By their numbers in this assay, from the lowest: compound 3; then compounds 2 and 4 (each within the scatter of the next); then compound 1.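

In this assay, the amino end on the shorter chain does not separate from the dimethylamino end (a difference of a 1.6-fold higher number from compound 2 to compound 4 (0.19 log units; within the scatter)), so at this chain length the two ethyl-free amine ends read alike. The amine tail of compound 4 keeps a clear gain over the ester-bearing tail (with a 4.9-fold lower number from compound 1 to compound 4 (0.69 log units; beyond the scatter)) although its nitrogen end carries no alkyl group, yet it stays clearly short of the 3-(diethylamino)propyl tail (with a 5.5-fold higher number from compound 3 to compound 4 (0.74 log units; beyond the scatter)). Nothing given here accounts for these steps.

Still open, on these data alone, is whether chain length or the diethylamino end carries the advantage of compound 3, since a 2-(diethylamino)ethyl tail or a 3-aminopropyl tail would separate the two. Also open, as far as these compounds go, is how a carboxylic acid or a hydroxyl in place of the amine at the chain end would read.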